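A few compounds are considered here, and "the series" means these few. Any claim that something is new, unique, unknown or untested is made for them only; others in the source may bear on it.

Working notes on the series. The shared core is carried by compound 1 `CC1CCC(=NNc2ccccc2)c2ncc(C(=O)O)c(=O)n21`, compound 2 `CC1CCC(=NNc2ccccc2C(=O)O)c2ncc(C(=O)NO)c(=O)n21` and compound 3 `CC1CCC(=NNc2cc([N+](=O)[O-])cc([N+](=O)[O-])c2)c2ncc(C(=O)O)c(=O)n21`. In a functional assay on the whole organism with Rattus norvegicus as the target (a higher number here means that more compound is needed for the effect, a lower number that less compound is needed), compound 1 gives 0.6 umol/kg, the lowest of the two numbers recorded; in this assay compound 3 gives 3.4 umol/kg, a gap that lies beyond the scatter. Within the data shown here, for compound 2 this assay reports only a limit, > 100 umol/kg, not a number; it is the one value sitting at the limit of > 100 umol/kg in this assay, at which 1 of the 3 values shown sits. Among the measured compounds shown here, no two measured compounds differ in a single place, so no measured step is available for guidance.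

Compound 4 `CC1CCC(=NNc2cccnc2)c2ncc(C(=O)O)c(=O)n21` is not yet measured. It differs from compound 1 in one place: pyridin-3-yl in place of phenyl on an amine nitrogen. The two measured numbers do not separate the effect of such a ring change from the other differences present, so only a small step, if any, is expected in this assay, perhaps toward a slightly higher number. The step from compound 1 to compound 4 is estimated at a 1.7-fold higher number from compound 1 to compound 4 (0.22 log units; within the scatter). For compound 4 the expected value in this assay is 1 umol/kg, with a range from 0.3 umol/kg to 3.5 umol/kg.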

Compound 4, dose for 50% inhibition: 0.54 umol/kg
The estimate for compound 4 lay 1.9-fold (0.27 log units) above the measured number; the range from low to high includes it.
By their numbers in this assay, from the lowest: compounds 4 and 1 (each within the scatter of the next); then compound 3. At a limit, above all of these: compound 2.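

In this assay, among these compounds, the exchange of phenyl for pyridin-3-yl on the amine nitrogen gives the first step that can be read at a single place: a 1.1-fold lower number from compound 1 to compound 4 (0.05 log units; within the scatter). Among the compounds shown here, the hydrogen-bond acceptor counted for pyridin-3-yl therefore leaves the number within the scatter of that of compound 1, which the earlier compounds, differing from one another in more than one place, could not show. Nothing measured here accounts for this step.

Going by these compounds, it remains open whether pyridin-2-yl or pyridin-4-yl at the same place would give a similar result, or whether a saturated ring such as piperidin-4-yl would. Also open, on these data alone, is whether the exchange would read the same on a ring carrying an amine or a methoxy group.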